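A few compounds are considered here, and "the series" means these few. Any claim that something is new, unique, unknown or untested is made for them only; others in the source may bear on it.

Measured in a functional assay on MCF7 cells (Homo sapiens) for antiproliferative activity, read by sulforhodamine B assay, with a stated time of 48 h; a lower number here means a stronger inhibitor, a higher number a weaker inhibitor:
- compound 1 `CCc1ccccc1NS(=O)(=O)c1ccc(N2CCNC2=O)cc1`: 350 nM
- compound 2 `O=C1NCCN1c1ccc(S(=O)(=O)Nc2ccc(F)cc2)cc1`: 690 nM
- compound 3 `Cc1ccc(NS(=O)(=O)c2ccc(N3CCNC3=O)cc2)cc1C`: 230 nM

Compound 2 gives 690 nM. Its nearest neighbour shows a 2.0-fold higher number from compound 1 to compound 2 (0.29 log units; within the scatter), and its furthest shows a 3.0-fold lower number from compound 2 to compound 3 (0.48 log units; beyond the scatter).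

Compound 4 `CC(C)(C)c1ccc(NS(=O)(=O)c2ccc(N3CCNC3=O)cc2)cc1` is the next case, with tert-butyl in place of fluoro on an aromatic carbon, para to a large group. Among the measured compounds shown here, no measured compound carries tert-butyl. The closest guide is a 3.0-fold lower number from compound 2 to compound 3 (0.48 log units; beyond the scatter), where 3,4-dimethylphenyl replaces 4-fluorophenyl. The other measured alkyl change, a 2.0-fold higher number from compound 1 to compound 2 (0.29 log units; within the scatter), offers weaker support.

The expected change is a 2.3-fold lower number from compound 2 to compound 4 (0.36 log units; beyond the scatter) in this assay, a modest move to a lower number.

The estimate for compound 4 is 300 nM, with an expected range of 110 nM to 750 nM.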

Compound 4, half-maximal inhibitory concentration: > 1000 nM
Compound 4 ended at the assay's limit (the forecaster's own chance of this, stated with the estimate: 3%); middle value at least 3.3-fold (0.52 log units) from the limit.
By their numbers in this assay, from the lowest: compounds 3, 1 and 2 (each within the scatter of the next, the first and the last beyond it). At a limit, above all of these: compound 4.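

Compound 4, with tert-butyl on an aromatic carbon para to a large group, gives > 1000 nM in this assay, which is a limit of the assay and not a number. Tert-butyl in place of fluoro gives an at least 1.4-fold higher number from compound 2 to compound 4 (0.16 log units; that floor lies within the scatter), so the step has only a floor and its true size stays unknown. Of the compounds shown, only compound 4 sits at the limit: the limit of > 1000 nM in this assay, at which 1 of the 4 values shown sits.

Still open, from the compounds shown here alone, is where compound 4 truly lies beyond that limit. Also open, going by these compounds, is how a methyl, an isopropyl, a methoxy or an amine would read on this carbon.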